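The source may report more compounds than this note shows. Statements on the series, on what has been measured and on what is new or still open speak of the compounds shown alone.

Among the compounds with values here, compound 2, `COc1ncc(-c2ccccc2)cc1[C@@H](c1ccccc1)[C@@](O)(CCN(C)C)c1cccc(F)c1F`, is the only compound of the pair with a number: in a toxicity assay on HeLa cells (Homo sapiens) for cytotoxicity (a lower number here means that less compound is tolerated, a higher number that more compound is tolerated), compound 2 gives 28.1 ug/mL. Compound 1, `COc1ncc(-c2ccccc2)cc1[C@@H](c1ccccc1)[C@@](O)(CCN(C)C)c1cc(F)ccc1F`, has no number in this assay, its entry reading "nd" (no result reported). Compound 3, `COc1ncc(-c2ccccc2)cc1[C@@H](c1ccccc1)[C@@](O)(CCN(C)C)c1cccc2ccccc12`, differs from compound 2 by naphthalen-1-yl in place of 2,3-difluorophenyl on a saturated chain carbon bound to an oxygen on a saturated carbon and two saturated chain carbons. Within the data shown here, no measured pair shows what such a change does here, so the expected step from compound 2 to compound 3 is set at a 1.8-fold lower number from compound 2 to compound 3 (0.24 log units; within the scatter), a modest shift toward less compound tolerated, barely beyond the scatter. Compound 3 is therefore estimated at 16 ug/mL, between 7 ug/mL and 40 ug/mL.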

Compound 3, half-maximal cytotoxic concentration: 30.4 ug/mL
The estimate for compound 3 lay 1.9-fold (0.28 log units) below the measured number; the measured number falls inside the stated range.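

Placing naphthalen-1-yl in place of 2,3-difluorophenyl on this saturated chain carbon gives a 1.1-fold higher number from compound 2 to compound 3 (0.03 log units; within the scatter) in this assay, the first step that can be read here. For this one pair, the exchange of two fluorines and one aromatic ring for an all-carbon group with two aromatic rings leaves the read-out within the scatter. No evidence on the reason for this accompanies the result. Still open, going by these compounds, is how a group carrying an amine or a carboxylic acid would read at this position. Compound 1 has no number, so no second difluorophenyl comparison can be read.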